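This account rests on a few compounds, and the source may have more. Where it says the series, first, only, none or still open, it means among the compounds named here.

Working notes on the series. Three compounds have numbers in an assay for inhibition of Fatty-acid amide hydrolase 1 (Rattus norvegicus); a lower number here means a stronger inhibitor, a higher number a weaker inhibitor. Compound 1 `CN(C)C(=O)c1cnc(C(=O)CCc2ccc(COc3ccccc3)cc2)o1` gives 6.7 nM. For the measured compounds named here, compound 2 `COC(=O)c1ccc(-c2cnc(C(=O)CCc3ccc(COc4ccccc4)cc3)o2)nc1` gives 3.5 nM; the only single-site step among the measured compounds, a 1.9-fold lower number from compound 1 to compound 2 (0.28 log units; within the scatter), concerns the group on the shared core and not the end of the chain. Compound 3 `COC(=O)c1cnc(C(=O)CCc2ccc(-c3ccccc3)cc2)o1` gives 1.5 nM, the lowest number of the three, with compound 2 nearest and compound 1 furthest, both gaps beyond the scatter.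

Compound 4 `COC(=O)c1cnc(C(=O)CCc2ccc(COc3ccccc3)cc2)o1` is the next member. Relative to compound 3 the change is phenoxymethyl in place of phenyl on an aromatic carbon. Going by the values given here, no measured pair differs at this place alone, so no step in this assay speaks to the change directly. What the values show is that the two compounds carrying phenoxymethyl, compound 1 and compound 2, sit at higher numbers than compound 3 with phenyl, while compound 4 keeps the methoxycarbonyl group of compound 3 on the shared core, closer to compound 2 than to compound 1 in that respect. On this basis compound 4 is expected to give a somewhat higher number than compound 3, roughly a 2.3-fold higher number from compound 3 to compound 4 (0.37 log units; beyond the scatter), a step near the edge of the scatter. The estimate for compound 4 in this assay is 3.5 nM, with a range from 1.5 nM to 9 nM.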

Compound 4, inhibition constant: 1.6 nM
Estimate against measurement, compound 4: 2.2-fold (0.34 log units) above; the measured number falls inside the stated range.
By their numbers in this assay, from the lowest: compounds 3 and 4 (each within the scatter of the next); then compounds 2 and 1 (each within the scatter of the next).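

In this assay, for the compounds shown here, the step of a 1.1-fold higher number from compound 3 to compound 4 (0.03 log units; within the scatter) is the first direct reading at this place, on an aromatic carbon para to a large group, and with methoxycarbonyl held on the shared core it does not separate phenoxymethyl from phenyl. With phenoxymethyl held constant, the group on the shared core can now be read in two steps: a 2.2-fold lower number from compound 2 to compound 4 (0.34 log units; beyond the scatter) for methoxycarbonyl in place of 5-(methoxycarbonyl)pyridin-2-yl and a 4.2-fold lower number from compound 1 to compound 4 (0.62 log units; beyond the scatter) for methoxy in place of dimethylamino on a carbonyl carbon. Among these three phenoxymethyl compounds the differences therefore sit with the group on the shared core, so the presence of phenoxymethyl does not by itself set a higher number in this set.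

On these data alone, whether a carboxylic acid or an amine in place of methoxycarbonyl on the shared core, or a longer chain in place of phenoxymethyl, would hold the number at this level remains open. Nothing available here bears on the reason for any of these steps.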